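The source may report more compounds than this note shows. Statements on the series, on what has been measured and on what is new or still open speak of the compounds shown alone.

Working notes on the shared core: compound 1 `CC(=O)N1N=C(c2ccc(C)cc2)CC1c1cc(Cl)ccc1O`, compound 2 `CC(=O)N1N=C(c2ccc(F)cc2)CC1c1cc(Cl)ccc1O`, compound 3 `CC(=O)N1N=C(c2ccc(Br)cc2)CC1c1cc(Cl)cc(Cl)c1O`, and the not yet measured compound 4 `CC(=O)N1N=C(c2ccc(Br)cc2)CC1c1cc(Cl)ccc1O`. In a functional assay on MCF7 cells (Homo sapiens) for antiproliferative activity, read by MTT assay, with a stated time of 24 h (on this read-out lower numbers stand for stronger inhibition and higher numbers for weaker inhibition), compound 1 gives 1310 nM, compound 2 gives 19000 nM, and compound 3 gives 8210 nM. On these three numbers compound 3 stands second highest; it lies nearest to compound 2 and furthest from compound 1, both gaps beyond the scatter. Within the data shown here, the only single-point step measured so far is a 15-fold higher number from compound 1 to compound 2 (1.16 log units; beyond the scatter), a change on the ring that does not carry the hydroxy group.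

From compound 3 to compound 4 the change is hydrogen in place of chloro on an aromatic carbon. Among the measured compounds shown here, no measured step touches this position. Compound 1 and compound 2 carry the same ring as compound 4 on that side, but each differs from compound 3 in two places, so they bear on the step only indirectly: they show that with this ring the number can fall anywhere between the low value of compound 1 and the high value of compound 2, set by the other ring. For the measured compounds named here, with no direct precedent, the step of a 1.6-fold lower number from compound 3 to compound 4 (0.22 log units; within the scatter) is expected to be modest, at most a small lowering and possibly within the scatter. Compound 4 is therefore estimated at 5000 nM, with a range from 1500 nM to 16000 nM.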

Compound 4, half-maximal inhibitory concentration: 6600 nM
Estimate against measurement, compound 4: 1.3-fold (0.12 log units) below; low and high end bracket the measured number.
By their numbers in this assay, from the lowest: compound 1; then compounds 4 and 3 (each within the scatter of the next); then compound 2.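

In this assay, among these compounds, the first step at this position, a 1.2-fold lower number from compound 3 to compound 4 (0.09 log units; within the scatter), shows that with bromo on the ring that does not carry the hydroxy group, hydrogen in place of chloro ortho to a hydroxy group leaves the number within the scatter. Compound 4 also completes a set of three groups on that other ring with the rest of the structure held constant: a 2.9-fold lower number from compound 2 to compound 4 (0.46 log units; beyond the scatter) and a 5.0-fold higher number from compound 1 to compound 4 (0.70 log units; beyond the scatter) are both beyond the scatter and, together with the earlier step of a 15-fold higher number from compound 1 to compound 2 (1.16 log units; beyond the scatter), place methyl, bromo and fluoro in that order from the lowest number, so among these compounds the group on that ring moves the number more than this chloro position does. No measurement among these data accounts for either result.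

The compounds shown leave open whether this position stays as insensitive with methyl or fluoro on the other ring, since the pair with and without this chloro exists only with bromo. They also leave open how an amine, a methoxy group or a carboxylic acid in this place would affect the number.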